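A few compounds are considered here, and "the series" means these few. Any claim that something is new, unique, unknown or untested is made for them only; others in the source may bear on it.

Among the compounds with values here, in a functional assay on MCF7 cells (Homo sapiens) for inhibition, read by MTT assay, with a stated time of 72 h (on this read-out lower numbers stand for stronger inhibition and higher numbers for weaker inhibition), compound 3 `COc1cc(NC(C)CCCNC(=O)NNC(=O)Nc2cccc(F)c2)c2ncccc2c1` gives 150 nM and holds the lowest of the three numbers so far, while compound 1 `COc1cc(NC(C)CCCNC(=O)Nc2ccc(Br)cc2)c2ncccc2c1` gives 2600 nM and compound 2 `COc1cc(NC(C)CCCNC(=O)Nc2ccc(F)cc2)c2ncccc2c1` gives 26000 nM as the highest. Compound 4 `COc1cc(NC(C)CCCNC(=O)Nc2ccc(Cl)cc2)c2ncccc2c1` has 4-chlorophenyl in place of ((3-fluorophenyl)carbamoyl)amino on an amide-type nitrogen and so resembles compound 1 and compound 2, which carry 4-bromophenyl and 4-fluorophenyl there. The steps of a 17-fold lower number from compound 1 to compound 3 (1.24 log units; beyond the scatter) and a 170-fold lower number from compound 2 to compound 3 (2.24 log units; beyond the scatter) are both large, and this change runs them backwards, so in this assay a large step to a higher number is expected. The swap of bromo for fluoro gave a 10-fold higher number from compound 1 to compound 2 (1.00 log units; beyond the scatter) as a modest step, and compound 4 is expected between those two values, nearer the lower one. The estimate means a 33-fold higher number from compound 3 to compound 4 (1.52 log units; beyond the scatter) overall. The estimate for compound 4 is 5000 nM (range 2000 nM to 13000 nM).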

Compound 4, half-maximal inhibitory concentration: 12000 nM
Beside the measured number, compound 4's estimate is 2.4-fold (0.38 log units) below it; measured number inside the range.
By their numbers in this assay, from the lowest: compound 3; then compound 1; then compound 4; then compound 2.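

Chloro in place of bromo gives a 4.6-fold higher number from compound 1 to compound 4 (0.66 log units; beyond the scatter) and chloro in place of fluoro gives a 2.2-fold lower number from compound 2 to compound 4 (0.34 log units; beyond the scatter) so the three halogens now form a graded order, with bromo lowest and fluoro highest. The third halogen also leaves the gap to the urea-extended group open, with 4-chlorophenyl in place of ((3-fluorophenyl)carbamoyl)amino giving an 80-fold higher number from compound 3 to compound 4 (1.90 log units; beyond the scatter) on this amide-type nitrogen. Nothing available explains this order. From the compounds shown here alone, whether 4-iodophenyl would extend the order remains open, as does how unsubstituted phenyl would compare. The compounds also cannot separate the contribution of the added carbamoylamino link from that of the fluoro group.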